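This account rests on a few compounds, and the source may have more. Where it says the series, first, only, none or still open, it means among the compounds named here.

Compound 1 `CCC1C(=O)N(C)c2cnc(Nc3ccc(S(=O)(=O)NCCCO)cc3)nc2N1c1ccn(C)n1`: 13400 nM in a functional assay on K562 cells (Homo sapiens) for antiproliferative activity, read by CCK-8 assay, with a stated time of 72 h; on this read-out lower numbers stand for stronger inhibition of growth and higher numbers for weaker inhibition of growth. Compound 2 `CCC1C(=O)N(C)c2cnc(Nc3ccc(S(=O)(=O)NCCO)cc3)nc2N1c1ccn(C)n1`: "not active" (no number reported). Compound 3 `CCC1C(=O)N(C)c2cnc(Nc3ccc(S(N)(=O)=O)cc3)nc2N1c1ccn(C)n1`: "not active" (no number reported).

Compound 3 stands without a number: in this assay compound 3 is recorded only as not active, and compound 2 shares that outcome, so compound 1 alone carries a measured value, and a weak one. Compound 4 `CCC1C(=O)N(C)c2cnc(Nc3ccc(S(=O)(=O)NC)cc3)nc2N1c1ccn(C)n1` differs from compound 3 by methyl in place of hydrogen on a sulfonamide nitrogen. Going by the values given here, no measured pair shows this change, so no step size can be read off. Because compound 3 is not active and compound 1 reaches only 13400 nM, any step in this assay is expected to be small, probably none beyond the usual scatter, leaving weak growth inhibition at best. Compound 4 is therefore estimated at 20000 nM, within 5000 nM to 80000 nM, and a report of no activity would not surprise.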

Compound 4, concentration for 50% growth inhibition: 2890 nM
Compound 4: the middle estimate sits 6.9-fold (0.84 log units) above what was measured, and the stated range ends above it.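

In this assay, the substituent on the sulfonamide nitrogen turns out to matter: compound 3, with a bare amino group, is recorded as not active, while compound 4, with methyl there, gives a measured value. Replacing the 2-hydroxyethyl of the chain with hydrogen gives a 4.6-fold lower number from compound 1 to compound 4 (0.67 log units; beyond the scatter) and so stronger inhibition of growth, which shows that the hydroxyl-ended chain is not needed for activity; chain length alone sets no simple trend, as compound 2 is recorded as not active. No measurement shown explains this gain.

On these data alone, whether ethyl or a second methyl on that nitrogen would do better remains open. So does the effect of a chain ending in an amine.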